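From acetyl to methylsulfonyl at the edge of the assay

The source may report more compounds than this note shows. Statements on the series, on what has been measured and on what is new or still open speak of the compounds shown alone.

In a functional assay on the whole organism with Mus musculus as the target (on this read-out lower numbers stand for an effect already at smaller amounts and higher numbers for an effect only at larger amounts of compound), compound 1 `Cc1c(C)c2c(c(C)c1N)CC(C)(CSc1ccc(F)cc1)O2` gives 17.9 mg/kg. Compound 2 `Cc1c(C)c2c(c(C)c1N)CC(C)(CN1CCN(c3ccccc3)CC1)O2` gives 13.1 mg/kg, and these two values lie within the usual scatter of each other. Compound 3 `CC(=O)Nc1c(C)c(C)c2c(c1C)CC(C)(C)O2` gives no number, only a limit: > 100 mg/kg. Among the three measured compounds, it alone stands at the limit of > 100 mg/kg in this assay, at which 1 of the 3 values shown sits. Compound 3 differs from each of the other two in more than one place, so the measurements contain no clean single-change comparison.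

Compound 4 `Cc1c(C)c2c(c(C)c1NS(C)(=O)=O)CC(C)(C)O2` keeps the core of compound 3 but carries methylsulfonyl in place of acetyl on a nitrogen on an aromatic ring. In other words, an acetamido group becomes a methanesulfonamido group.

Among the compounds with values here, with no measured step to serve as a guide, the expectation in this assay is for no shift beyond the usual scatter, in either direction. Within the data shown here, the only starting point for compound 3 is > 100 mg/kg, which is a limit. The expected change is small, and the estimate is a step that the limit leaves unreadable from compound 3 to compound 4. For compound 4 the estimated dose is 130 mg/kg, with an expected range from 50 mg/kg to 300 mg/kg.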

Compound 4, dose for 50% inhibition: > 100 mg/kg
Compound 4: a limit, no number; the forecaster's own chance of this, stated with the estimate: 65%; the middle value does not contradict the limit.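

Compound 3 and compound 4 each give only a limit and not a number, so no step between them can be read: the limit of > 100 mg/kg in this assay, at which 2 of the 4 values shown sit.

The compounds shown leave open whether methylsulfonyl in place of acetyl on a nitrogen on an aromatic ring changes the dose in this assay at all, and in which direction.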